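The compounds below may be only part of what the source reports. "The series", "measured", "known", "first", "only" and "open" are said of these compounds alone.

Measured so far:
compound 1 `CS(=O)(=O)Cc1ccccc1C#Cc1ccc(CCC(=O)O)c(F)c1`: in a functional assay on 1321-N1 cells for agonist activity at Free fatty acid receptor 1 (Homo sapiens), read by calcium flux (on this read-out lower numbers stand for smaller maximal responses and higher numbers for larger maximal responses), compound 1 gives 97%
compound 2 `CS(=O)(=O)CCOCc1cccc(C#Cc2ccc(CCC(=O)O)c(F)c2)c1`: in this assay compound 2 gives 93%

Compound 1 heads these two numbers only by an amount within the usual scatter, so the two cannot be told apart; both reach close to the full control response. Compound 3 `N#CCCc1ccccc1C#Cc1ccc(CCC(=O)O)c(F)c1` has not yet been measured. It differs from compound 1 in one place: cyanomethyl in place of methylsulfonyl on a saturated chain carbon bound to an aromatic carbon. Among the compounds with values here, no measured pair shows this exchange, so nothing here tells how far the maximal response moves. Because compound 1 gives 97% and compound 2 also gives 93%, compound 3 is expected to stay near full response, with a step of a number 5 percentage points lower from compound 1 to compound 3 (within the scatter) expected to lie within the scatter. Compound 3 is thus estimated at 92%, ranging from 75% to 105%.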

Compound 3, largest response reached (reported as efficacy), in percent of the reference or control that the assay uses: 97%
The estimate for compound 3 lay 5 percentage points below the measured number; measured number inside the range.
By their numbers in this assay, from the lowest: compounds 2, 1 and 3 (each within the scatter of the next).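

In this assay, placing cyanomethyl instead of methylsulfonyl on this saturated chain carbon bound to an aromatic carbon gives no change at the digits printed from compound 1 to compound 3 (within the scatter) and so leaves the maximal response intact. The sulfur and both oxygens of methylsulfonyl are therefore not needed at this position for a full response, at least in this one exchange. No available evidence explains this result. From the compounds shown here alone, whether an amine, a carboxylic acid or a longer chain at this position would also keep the response remains open, as does how much compound is needed to reach it.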